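The source may report more compounds than this note shows. Statements on the series, on what has been measured and on what is new or still open speak of the compounds shown alone.

Measured so far:
Compound 1 `Oc1cccc(-c2cc(-c3ccccc3)cc(-c3cccc(O)c3)n2)c1`: 12800 nM
Compound 2 `Oc1ccc(-c2cc(-c3ccccc3)cc(-c3ccc(O)cc3)n2)cc1`: 6700 nM
Compound 3 `Oc1cccc(-c2cc(-c3ccccc3)nc(-c3ccccc3)c2)c1`: 19500 nM

In a functional assay on MDA-MB-231 cells (Homo sapiens) for cytotoxicity, read by ELISA, with a stated time of 2 days (on this read-out higher numbers stand for weaker inhibition and lower numbers for stronger inhibition), compound 3 gives 19500 nM, which lies within the usual scatter of compound 1 at 12800 nM. Compound 2, at 6700 nM, reads lower than compound 3, and that gap lies beyond the scatter. Compound 4 `Oc1cccc(-c2cc(-c3ccccc3)nc(-c3cccnc3)c2)c1` carries pyridin-3-yl in place of phenyl on an aromatic carbon. Going by the values given here, no measured pair here shows this exchange, so the expectation rests only on the narrow spread of these three values. The expected step is small and lies within the scatter, a 1.4-fold lower number from compound 3 to compound 4 (0.14 log units; within the scatter), with a slight lean towards stronger inhibition. For compound 4 the estimated value is 14000 nM, with an expected range of 6000 nM to 32000 nM.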

Compound 4, half-maximal inhibitory concentration: 22800 nM
For compound 4 the middle estimate is 1.6-fold (0.21 log units) below the measured one; measured number inside the range.
By their numbers in this assay, from the lowest: compounds 2, 1, 3 and 4 (each within the scatter of the next, the first and the last beyond it).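

In this assay, pyridin-3-yl in place of phenyl on the aromatic carbon next to the ring nitrogen gives a 1.2-fold higher number from compound 3 to compound 4 (0.07 log units; within the scatter). This first single-place step shows that, at this position, a ring nitrogen and a hydrogen-bond acceptor can enter without moving the number beyond the scatter. No accompanying measurement bears on this result, so it stays an observation without an explanation.

Going by these compounds, whether a carboxylic acid or an amine at this position would leave the number equally unmoved remains open. So does whether the same exchange would read alike on the core of compound 2.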